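Adding a methoxy to the fused ring of compound 2

A few compounds are considered here, and "the series" means these few. Any claim that something is new, unique, unknown or untested is made for them only; others in the source may bear on it.

Of the compounds shown here, three sharing one core have been tested in a functional assay on DU-145 cells (Homo sapiens) for cytotoxicity, read by MTT assay, with a stated time of 48 h; a higher number here means a weaker inhibitor, a lower number a stronger inhibitor. Compound 1 `CCOC(=O)c1c(-c2cc3ccccc3oc2=O)nn(-c2cccc(C)c2)c1C(=O)OCC` gives 47000 nM, compound 2 `CCOC(=O)c1c(-c2cc3ccccc3oc2=O)nn(-c2cccc(Cl)c2)c1C(=O)OCC` gives 35000 nM, and compound 3 `CCOC(=O)c1c(-c2cc3ccccc3oc2=O)nn(-c2ccc(Cl)cc2)c1C(=O)OCC` gives 26000 nM. Compound 2 has the second highest of these three numbers, with a 1.3-fold lower number from compound 1 to compound 2 (0.13 log units; within the scatter) and a 1.3-fold lower number from compound 2 to compound 3 (0.13 log units; within the scatter), and the remaining step is a 1.8-fold lower number from compound 1 to compound 3 (0.26 log units; within the scatter). Compound 4 `CCOC(=O)c1c(-c2cc3cc(OC)ccc3oc2=O)nn(-c2cccc(Cl)c2)c1C(=O)OCC` differs from compound 2 by methoxy in place of hydrogen on an aromatic carbon. Going by the values given here, none of the measured steps touches this fused ring; each of them changes only the group on the aromatic nitrogen, and each stayed within the scatter. Compound 4 is therefore expected to give about 30000 nM, between 10000 nM and 90000 nM. This amounts to an expected 1.2-fold lower number from compound 2 to compound 4 (0.07 log units; within the scatter), nothing beyond the scatter.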

Compound 4, half-maximal inhibitory concentration: 29000 nM
Compound 4: middle estimate off by 1.0-fold (0.01 log units), on the high side; the measured number falls inside the stated range.
By their numbers in this assay, from the lowest: compounds 3, 4, 2 and 1 (each within the scatter of the next).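

This is the first change shown on the fused ring rather than on the group on the aromatic nitrogen, and in this assay methoxy in place of hydrogen gives a 1.2-fold lower number from compound 2 to compound 4 (0.08 log units; within the scatter), so this position tolerates methoxy with no change beyond the scatter. The same holds only for the pair of compounds shown here. No evidence given explains this result. Going by these compounds, whether an amine, a carboxylic acid or a longer chain at this position would shift the number beyond the scatter remains open. So does whether methoxy would behave alike with a different group on the aromatic nitrogen.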